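The source may report more compounds than this note shows. Statements on the series, on what has been measured and on what is new or still open speak of the compounds shown alone.

In an assay on NIH3T3 cells with Urotensin-2 receptor (Homo sapiens) as the target (on this read-out higher numbers stand for larger maximal responses and lower numbers for smaller maximal responses), three compounds have been measured. Compound 1, `COc1ccc(NC(=O)OC(CCN(C)C)c2ccc(Cl)cc2)cc1`, gives 170%. Compound 2, `CN(C)CCC(OC(=O)NCc1ccccc1)c1ccc(Cl)cc1`, gives 180%. Compound 3, `COc1ccc(NC(=O)NC(CCN(C)C)c2ccc(Cl)cc2)cc1`, gives 195%.

Compounds 1 and 2 share one core and differ in a single place: benzyl in place of 4-methoxyphenyl on an amide-type nitrogen. That change produced a step of a number 10 percentage points higher from compound 1 to compound 2 (within the scatter). Compound 3 carries the same 4-methoxyphenyl group as compound 1 but on a different core, and the difference between the two cores is not broken down here. Compound 3 stands highest of the three numbers, beyond the scatter from both compound 2 and compound 1.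

Compound 4, `CN(C)CCC(NC(=O)NCc1ccccc1)c1ccc(Cl)cc1`, has not yet been measured in this assay. It differs from compound 3 by benzyl in place of 4-methoxyphenyl on an amide-type nitrogen, the same change as seen between compound 1 and compound 2, at the same place. From compound 3 to compound 4 the expected step is a number 7 percentage points higher from compound 3 to compound 4 (within the scatter), since the same change earlier gave a number 10 percentage points higher from compound 1 to compound 2 (within the scatter). This rests on a single earlier instance only. Compound 4 is therefore estimated to give about 202%, expected to fall between 175% and 230%.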

Compound 4, largest response reached (reported as efficacy), in percent of the reference or control that the assay uses: 179%
Compound 4: the middle estimate sits 23 percentage points above what was measured; the range from low to high includes it.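

In this assay, putting benzyl in place of 4-methoxyphenyl on the amide-type nitrogen of the core of compound 3 gives a number 16 percentage points lower from compound 3 to compound 4 (beyond the scatter). The change therefore does not carry over as a fixed step from the core of compound 1 to the core of compound 3: the same change on two cores in this assay, a number 10 percentage points higher (within the scatter) from compound 1 to compound 2 and a number 16 percentage points lower (beyond the scatter) from compound 3 to compound 4, 26 percentage points apart, beyond the scatter of two such steps. Among these compounds, this shows that, for these two pairs, the result of the change depends on the core it sits on, but with only one pair per core it does not show why, or what the change would do on any further core.

The change also removes the methoxy group and adds a carbon link to the ring in a single move, so the compounds shown cannot tell these two parts apart. Plain phenyl or 4-methoxybenzyl on the same nitrogen of each core would separate them, and either group would show which part goes with the differing steps.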